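Working notes: bromo removal from compound 2 to compound 3

A few compounds are considered here, and "the series" means these few. Any claim that something is new, unique, unknown or untested is made for them only; others in the source may bear on it.

Measured compounds:
compound 1, `C=C[C@@H]1OC(c2ccc(Cl)cc2)=N[C@H]1S`, in an assay on isolated protein for inhibition of matrix metalloproteinase-9 (Homo sapiens) (a higher number here means a weaker inhibitor, a lower number a stronger inhibitor), gives > 100000 nM; this is a limit of the assay, not a number.
compound 2, `C=C[C@@H]1OC(/C=C/c2ccc(Br)cc2)=N[C@H]1CO`, in this assay gives 22000 nM.

Among the compounds with values here, compound 2 holds the only numerical value shown in this assay. Compound 1 sits at the limit of > 100000 nM in this assay, at which 1 of the 2 values shown sits. Within the data shown here, no step between the two can therefore be sized, and no measured step exists at all.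

Compound 3 is `C=C[C@@H]1OC(/C=C/c2ccccc2)=N[C@H]1CO`, not yet measured in this assay. It differs from compound 2 by hydrogen in place of bromo on an aromatic carbon. Among the measured compounds shown here, with no measured pair addressing this change, the expectation rests on the single value of compound 2 alone. A modest weakening is expected, estimated at a 1.8-fold higher number from compound 2 to compound 3 (0.26 log units; within the scatter), though a result within the scatter would not surprise. For compound 3 the expected value in this assay is 40000 nM, with a range from 15000 nM to 150000 nM.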

Compound 3, inhibition constant: 40000 nM
The estimate for compound 3 equals the measured number at the digits printed, within the range that was stated.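

In this assay, within the data shown here, hydrogen in place of bromo on an aromatic carbon, para to a large group, gives a 1.8-fold higher number from compound 2 to compound 3 (0.26 log units; within the scatter), the first step that can be sized. This position therefore tolerates the loss of the bromo without a change beyond the usual scatter, and the measured series shows no need for this halogen to obtain a numerical value in this assay. Nothing shown here accounts for this result in terms of a cause.

Among these compounds, compound 1 gives > 100000 nM, which is a limit of the assay and not a number, and it differs from the other compounds in more than one place, so no step to it can be read. Still open, going by these compounds, is whether an amine, a carboxylic acid or a longer chain at this aromatic carbon would give a step beyond the scatter from compound 3.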